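The source may report more compounds than this note shows. Statements on the series, on what has been measured and on what is new or still open speak of the compounds shown alone.

Three compounds share one core and were tested in a functional assay on OVCAR-3 cells (Homo sapiens) for cytotoxicity; on this read-out higher numbers stand for weaker inhibition of growth and lower numbers for stronger inhibition of growth. Compound 1, `OCCCCC#Cc1ccccc1C#Cc1ccccn1`, gives 26100 nM. Compound 2, `OCCCCC#Cc1ccccc1C#Cc1cccc(O)c1`, gives 20000 nM, and compound 3, `OCCCCC#Cc1ccccc1C#Cc1ccc(O)cc1`, gives 14800 nM. The three numbers sit close together: a 1.3-fold lower number from compound 1 to compound 2 (0.12 log units; within the scatter), a 1.8-fold lower number from compound 1 to compound 3 (0.25 log units; within the scatter) and a 1.4-fold lower number from compound 2 to compound 3 (0.13 log units; within the scatter) all lie within the scatter, so none of the three can be called more or less active than another. Compound 4, `OCCCCC#Cc1ccccc1C#Cc1ccc(C(F)(F)F)cc1`, differs from compound 3 by trifluoromethyl in place of hydroxy on an aromatic carbon. Among the measured compounds shown here, no measured step swaps hydroxy for trifluoromethyl, but every change made so far to the group on the triple-bonded carbon left the number within the scatter. Compound 4 is therefore expected to show a 1.1-fold higher number from compound 3 to compound 4 (0.03 log units; within the scatter) in this assay. The estimate for compound 4 is 16000 nM, within a range from 5000 nM to 50000 nM.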

Compound 4, concentration for 50% growth inhibition: 17800 nM
The estimate for compound 4 lay 1.1-fold (0.05 log units) below the measured number; measured number inside the range.
By their numbers in this assay, from the lowest: compounds 3, 4, 2 and 1 (each within the scatter of the next).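

In this assay, trifluoromethyl in place of hydroxy on an aromatic carbon para to a large group gives a 1.2-fold higher number from compound 3 to compound 4 (0.08 log units; within the scatter). The earlier compounds shown here all carried a hydrogen-bond donor on a phenyl ring or a pyridin-2-yl ring, whereas compound 4 has trifluoromethyl, with 0 hydrogen-bond donors, and its number still stays within the scatter of compound 3. No evidence explains this result.

Going by these compounds, whether an amine or a carboxylic acid on this aromatic carbon would move the number beyond the scatter stays open. On these data alone, the chain ending in hydroxy is the same in all four compounds, so the effect of changing it also stays open.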